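Removing the acetonide from the triazole side chain

The compounds below may be only part of what the source reports. "The series", "measured", "known", "first", "only" and "open" are said of these compounds alone.

Compound 1, `CC1(C)OCC(Cn2cc(Cn3c4c(c5ccccc53)C(=O)c3c[n+]([O-])c5ccccc5c3C4=O)nn2)O1`, gives 80 nM in a functional assay on A549 cells (Homo sapiens) for cytotoxicity, read by MTT assay, with a stated time of 72 h; a lower number here means a stronger inhibitor, a higher number a weaker inhibitor.
Compound 2, `O=C1c2c[n+]([O-])c3ccccc3c2C(=O)c2c1c1ccccc1n2CCN1CCCC1`, gives 410 nM in this assay.
Compound 3, `CC1(C)O[C@@H](CO)[C@H](Cn2cc(Cn3c4c(c5ccccc53)C(=O)c3c[n+]([O-])c5ccccc5c3C4=O)nn2)O1`, gives 370 nM in this assay.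

Compound 3 holds the second-highest number of the three, and its value sits within the scatter of compound 2, so no order between those two can be read. Going by the values given here, the only step beyond the scatter is a 4.6-fold higher number from compound 1 to compound 3 (0.67 log units; beyond the scatter).

Compound 4, `O=C1c2c[n+]([O-])c3ccccc3c2C(=O)c2c1c1ccccc1n2Cc1cn(C[C@@H](O)CO)nn1`, differs from compound 3 by 1,2-dihydroxyethyl in place of 5-(hydroxymethyl)-2,2-dimethyl-1,3-dioxolan-4-yl on a saturated chain carbon bound to an aromatic nitrogen. Among the compounds with values here, no measured pair tells how the 1,2-dihydroxyethyl group compares with the cyclic acetonide it replaces; the step from compound 1 to compound 3 only shows that growing the substituent on this chain raised the number modestly. With the supporting evidence this thin, the expectation is for compound 4 to stay near compound 3, with a modest tilt to a higher number, so the estimated step is a 1.5-fold higher number from compound 3 to compound 4 (0.17 log units; within the scatter). Compound 4 is thus expected to give about 550 nM in this assay, within a range of 180 nM to 1700 nM.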

Compound 4, half-maximal inhibitory concentration: 390 nM
Estimate against measurement, compound 4: 1.4-fold (0.15 log units) above; the measured number falls inside the stated range.
By their numbers in this assay, from the lowest: compound 1; then compounds 3, 4 and 2 (each within the scatter of the next).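

In this assay, the open 1,2-dihydroxyethyl group cannot be told apart from the ring-bearing 5-(hydroxymethyl)-2,2-dimethyl-1,3-dioxolan-4-yl group on this saturated chain carbon bound to an aromatic nitrogen, with a 1.1-fold higher number from compound 3 to compound 4 (0.02 log units; within the scatter) despite the loss of the ring and of both methyl-bearing carbons' worth of heavy atoms. The separation from the 2,2-dimethyl-1,3-dioxolan-4-yl group persists, at a 4.9-fold higher number from compound 1 to compound 4 (0.69 log units; beyond the scatter) and thus of the size seen for compound 3, so among these compounds both hydroxyl-bearing side chains stand apart from compound 1. The pyrrolidine chain gives no separation either, with a 1.1-fold lower number from compound 2 to compound 4 (0.02 log units; within the scatter) as its step.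

On these data alone, how a carboxylic acid, a primary amine or a longer chain at this place would read remains open. No evidence accompanies these numbers to explain them.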